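A few compounds are considered here, and "the series" means these few. Any claim that something is new, unique, unknown or untested is made for them only; others in the source may bear on it.

In a physicochemical assay for solubility, read by chemiluminescence, measured as kinetic solubility (on this read-out lower numbers stand for lower solubility and higher numbers for higher solubility), compound 1 `COc1nn(C)c2ncnc(NS(=O)(=O)c3cccc(Cl)c3Cl)c12` gives >= 581000 nM, which is a limit and not a number. Among the measured compounds shown here, compound 2 `COc1nn(C(C)C)c2ncnc(NS(=O)(=O)c3cccc(Cl)c3Cl)c12` gives 404000 nM, the only full number so far, so it cannot yet be ranked against a second measured value. Compound 3 `COc1nn(CC(N)=O)c2ncnc(NS(=O)(=O)c3cccc(Cl)c3Cl)c12` shares the core of compound 2 and differs in one place, with carbamoylmethyl in place of isopropyl on an aromatic nitrogen. For the measured compounds named here, one measured step bears on this, since it also swaps the group on an aromatic nitrogen, there isopropyl in place of methyl. Going by the values given here, with an at least 1.4-fold lower number from compound 1 to compound 2 (0.15 log units; that floor lies within the scatter) as the only guide, no step beyond the scatter is expected in this assay, though a single step whose size is only a floor is thin support. The estimated change is a 1.1-fold higher number from compound 2 to compound 3 (0.03 log units; within the scatter). For compound 3 the expected value is 430000 nM, with an estimated range from 220000 nM to 600000 nM.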

Compound 3, solubility: >= 490000 nM
Compound 3: only a limit was reported; the forecaster's own chance of this, stated with the estimate: 30%; middle value at least 1.1-fold (0.05 log units) from the limit.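

In this assay compound 3 gives >= 490000 nM, which is a limit of the assay and not a number. Among the compounds shown here, until now the aromatic nitrogen had carried only plain carbon groups, and carbamoylmethyl is the first group here to bring a hydrogen-bond donor and a hydrogen-bond acceptor to that place; the change from isopropyl gives an at least 1.2-fold higher number from compound 2 to compound 3 (0.08 log units; that floor lies within the scatter). For the compounds shown here, the step from compound 1 to compound 3 cannot be read, since both values are limits, so compound 2 remains the only compound with a full number.

On these data alone, how far compound 1 and compound 3 really lie from compound 2 stays open, as only floors are known. Also open, as far as these compounds go, is what this assay would show with a carboxylic acid or an amine on this nitrogen, or with a longer chain.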